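A few compounds are considered here, and "the series" means these few. Any claim that something is new, unique, unknown or untested is made for them only; others in the source may bear on it.

Three compounds share one core, differing only in the group carried on the urea nitrogen. Compound 1 `CCCNC(=O)Nc1c(OCCCn2cnc(-c3ccccc3)c2)cccc1N(C)C` carries a propyl group and gives 660 nM in an assay for inhibition of acyl-CoA:cholesterol acyltransferase (Oryctolagus cuniculus), using microsomes; on this read-out higher numbers stand for weaker inhibition and lower numbers for stronger inhibition. Compound 2 `CCCCCNC(=O)Nc1c(OCCCn2cnc(-c3ccccc3)c2)cccc1N(C)C` carries a pentyl group and gives 31 nM. Compound 3 `CN(C)c1cccc(OCCCn2cnc(-c3ccccc3)c2)c1NC(=O)NC1CCCCC1` carries a cyclohexyl group and gives 73 nM; among the three numbers it stands second highest, closest to compound 2 and well apart from compound 1.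

Compound 4 `CN(C)c1cccc(OCCCn2cnc(-c3ccccc3)c2)c1NC(=O)NC1CCCC1` is not yet measured; it differs from compound 3 by cyclopentyl in place of cyclohexyl on an amide-type nitrogen.

Among the measured compounds shown here, three measured steps bear on this position. The step of a 21-fold lower number from compound 1 to compound 2 (1.33 log units; beyond the scatter) and the step of a 9.0-fold lower number from compound 1 to compound 3 (0.96 log units; beyond the scatter) show that lengthening or closing up the group here moved the number down strongly, while a 2.4-fold higher number from compound 2 to compound 3 (0.37 log units; beyond the scatter) shows that pentyl and cyclohexyl sit close together. For the measured compounds named here, no measured pair shows a ring being shortened by one member, so the expectation rests on compound 1 alone pointing toward higher numbers for the leaner groups.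

For compound 4 a modest rise is therefore expected, a step of a 1.8-fold higher number from compound 3 to compound 4 (0.25 log units; within the scatter), giving an estimated value of 130 nM with a range from 50 nM to 350 nM.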

Compound 4, half-maximal inhibitory concentration: 240 nM
Beside the measured number, compound 4's estimate is 1.8-fold (0.27 log units) below it; low and high end bracket the measured number.
By their numbers in this assay, from the lowest: compound 2; then compound 3; then compound 4; then compound 1.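

In this assay, among the compounds shown here, changing only the ring size on the amide-type nitrogen has a clear effect: cyclopentyl in place of cyclohexyl gives a 3.3-fold higher number from compound 3 to compound 4 (0.52 log units; beyond the scatter) and is the first measured step to test a ring of a different size. Against the open chains, the smaller ring gives a 7.7-fold higher number from compound 2 to compound 4 (0.89 log units; beyond the scatter) but also a 2.8-fold lower number from compound 1 to compound 4 (0.44 log units; beyond the scatter) and so lies between the propyl and pentyl compounds. The cyclohexyl ring stays closer to the pentyl chain of compound 2 than the cyclopentyl ring does, so among these four compounds, the ring with one carbon fewer loses much of the ground gained over propyl.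

No measurement shown here explains why one ring carbon matters this much. From the compounds shown here alone, whether a cycloheptyl ring or a hexyl chain would lower the number further remains open, as does the effect of a piperidinyl ring carrying an amine.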